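Cytotoxicity notes on three measured analogues and one proposed

The source may hold more compounds than are shown below. What is called first, only, known or untested is meant among the compounds shown, and "the series" means these compounds.

Measured so far in an ADME assay on PC-3 cells (Homo sapiens) for cytotoxicity, read by WST assay, tested at 100 uM; on this read-out higher numbers stand for more inhibition at the one concentration tested (going by the name of the read-out) and lower numbers for less inhibition:
compound 1 `O=C(Nc1cccc(Oc2ccccn2)c1)C1CCCN(C(=O)c2cc(C(F)(F)F)cc(C(F)(F)F)c2)C1` gives 0%
compound 2 `CC(C)(C)CC(=O)Nc1cccc(C(=O)N2CCCC(C(=O)Nc3ccc(Cl)cc3)C2)c1` gives 0%
compound 3 `O=C(Nc1cccc(CN2CCCC2)c1)C1CCCN(C(=O)c2cc(C(F)(F)F)cc(C(F)(F)F)c2)C1` gives 51%

Compound 2 stands level with compound 1 at the digits shown; together they are the lowest of the three numbers, and compound 3 lies furthest from both. Within the data shown here, the one measured step is a number 51 percentage points higher from compound 1 to compound 3 (beyond the scatter), a large rise brought by (pyrrolidin-1-yl)methyl in place of (pyridin-2-yl)oxy on an aromatic carbon.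

Compound 4 `C=Cc1cccc(C(=O)N2CCCC(C(=O)Nc3ccc(Cl)cc3)C2)c1` differs from compound 2 by vinyl in place of (neopentylcarbonyl)amino on an aromatic carbon. Among the measured compounds shown here, that measured step concerns a different aromatic carbon of the shared core, so no measured step bears directly on this change; nothing shows what removing a (neopentylcarbonyl)amino group does in this assay. For the measured compounds named here, with compound 2 at the bottom of the range and no comparable step to lean on, no movement beyond the scatter is expected: the step from compound 2 to compound 4 is estimated as a number 5 percentage points higher from compound 2 to compound 4 (within the scatter). Compound 4 is therefore expected to give about 5%, with a range of 0% to 25%.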

Compound 4, a percentage reported as inhibition, at one concentration (the size of the read-out at that concentration, not a potency): 0%
Compound 4: the middle estimate sits 5 percentage points above what was measured; measured number inside the range.
By their numbers in this assay, from the lowest: compounds 1, 2 and 4 (each within the scatter of the next); then compound 3.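

In this assay, vinyl in place of (neopentylcarbonyl)amino on an aromatic carbon, meta to a large group, gives no change at the digits printed from compound 2 to compound 4 (within the scatter). Among these compounds, this is the first step read at this place, and it shows that a group of 2 heavy atoms with no hydrogen-bond donor or acceptor leaves the number where the group of 8 heavy atoms with one of each had it. No measurement available here explains this absence of change.

Going by these compounds, whether an amine or a carboxylic acid on this aromatic carbon would lift the number stays open. With compound 2 at 0% and compound 4 at 0%, the two compounds also cannot show whether either group lowers the read-out, since neither number leaves room to fall.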